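Iodo in place of furan-3-yl: an untested change

This account rests on a few compounds, and the source may have more. Where it says the series, first, only, none or still open, it means among the compounds named here.

Within the data shown here, compound 1 `COc1ncnc2c1c(-c1ccoc1)cn2[C@@H]1O[C@H](CO)[C@@H](O)[C@H]1O` gives 110 nM in a functional assay on HCT-116 cells (Homo sapiens), read by MTT assay, with a stated time of 72 h (on this read-out higher numbers stand for weaker inhibition and lower numbers for stronger inhibition), the highest of the two numbers so far. Compound 2 `CSc1ncnc2c1c(-c1ccoc1)cn2[C@@H]1O[C@H](CO)[C@@H](O)[C@H]1O` gives 40 nM; the step of a 2.8-fold lower number from compound 1 to compound 2 (0.44 log units; beyond the scatter) goes with methylsulfanyl in place of methoxy on an aromatic carbon. Compound 3 `COc1ncnc2c1c(I)cn2[C@@H]1O[C@H](CO)[C@@H](O)[C@H]1O` differs from compound 1 by iodo in place of furan-3-yl on an aromatic carbon. No measured step bears on this change: the single step known concerns methoxy against methylsulfanyl elsewhere on the shared core, so no shown number fixes direction or size. For compound 3 the expected step is a 3.6-fold higher number from compound 1 to compound 3 (0.56 log units; beyond the scatter), beyond the scatter toward a higher number, with wide uncertainty. Compound 3 is estimated at 400 nM, between 80 nM and 3000 nM.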

Compound 3, half-maximal inhibitory concentration: > 20000 nM
Compound 3 ended at the assay's limit; the forecaster's own chance of this, stated with the estimate: 10%; at least 50-fold (1.69 log units) between middle value and limit.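

In this assay compound 3 gives > 20000 nM, which is a limit of the assay and not a number: the limit of > 20000 nM in this assay, at which 1 of the 3 values shown sits.

Iodo in place of furan-3-yl gives an at least 180-fold higher number from compound 1 to compound 3 (2.25 log units; beyond the scatter). The earlier step touched only methoxy against methylsulfanyl, whereas this one shows that the group on this aromatic carbon can decide whether the series reads in the nanomolar range at all.

Open, from the compounds shown here alone, is whether the furan-3-yl ring itself is needed or whether another group here, such as phenyl, thiophene, an amine or a short alkyl chain, would serve. Also open, going by these compounds, is whether the same change behaves alike with methylsulfanyl in place of methoxy.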